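Dropping a methyl from an aryl sulfone in a receptor binding assay

The source may hold more compounds than are shown below. What is called first, only, known or untested is meant among the compounds shown, and "the series" means these compounds.

Measured so far:
- compound 1, `Cc1ccc(S(=O)(=O)c2cnc3c(F)cccc3c2N2CCC(C)CC2)cc1`: 93%
- compound 2, `CC1CCN(c2c(S(=O)(=O)c3ccc(F)cc3)cnc3ccc(Cl)cc23)CC1`: 89%

Both compounds share a core carrying a methyl-substituted piperidine and an aryl sulfone. In a binding assay on isolated protein for displacement of a labelled ligand from metabotropic glutamate receptor 5 (Homo sapiens), with a stated time of 60 min, tested at 1 uM (a higher number here means more inhibition at the concentration tested (going by the name of the read-out), a lower number less inhibition), compound 1 gives 93%. In the same test compound 2 gives 89%. These two numbers lie within the usual scatter of each other, so compound 1 does not stand apart from compound 2 on the numbers shown; both sit near the top of the scale.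

Compound 3, `CC1CCN(c2c(S(=O)(=O)c3ccccc3)cnc3c(F)cccc23)CC1`, has not yet been tested. It differs from compound 1 in one place: hydrogen in place of methyl on an aromatic carbon. Read one bond further out, the 4-methylphenyl of compound 1 becomes a plain phenyl.

Within the data shown here, no step between measured compounds shows what such a change does. Compound 2, which also carries a phenyl without a methyl, still gives 89%, so a high number seems plausible. The step from compound 1 to compound 3 is therefore expected to be small, most likely a slight drop, about a number 8 percentage points lower from compound 1 to compound 3 (within the scatter). For compound 3 the estimate is 85%, with a likely range from 65% to 97%.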

Compound 3, a percentage reported as inhibition, at one concentration (the size of the read-out at that concentration, not a potency): 13%
Compound 3: the middle estimate sits 72 percentage points above what was measured, and the stated range ends above it.
By their numbers in this assay, from the lowest: compound 3; then compounds 2 and 1 (each within the scatter of the next).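

In this assay, among these compounds, the single change from 4-methylphenyl to phenyl gives a number 80 percentage points lower from compound 1 to compound 3 (beyond the scatter), so on the core of compound 1 this one methyl, para to a large group, is far from a spare detail. Among the compounds shown here, the earlier compounds could not show this, as neither of them differs from the other in only one place, and this is the first pair that isolates the group. Nothing available bears on why the number falls so far.

On these data alone, it remains open whether a methyl specifically is needed here or whether another group at this place, such as an ethyl, a methoxy or an amine, would restore the number. As far as these compounds go, each number is also the size of the read-out at a single concentration, so how much potency separates compound 1 from compound 3 remains open, as does whether removing this methyl would have the same effect on a core carrying different substituents.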